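The compounds below may be only part of what the source reports. "The series", "measured", "known", "first", "only" and "open" are said of these compounds alone.

Measured in an in vivo functional assay on the whole organism for inhibition, with Rattus norvegicus as the target; on this read-out lower numbers stand for an effect already at smaller amounts and higher numbers for an effect only at larger amounts of compound:
- compound 1 `CCCCc1nc(C)c(CC(=O)O)c(=O)n1Cc1ccc(-c2ccccc2-c2nnn[nH]2)cc1`: 0.13 mg/kg
- compound 2 `CCCCc1nc(C)c(CC(=O)N(C)C)c(=O)n1Cc1ccc(-c2ccccc2-c2nnn[nH]2)cc1`: 0.018 mg/kg
- compound 3 `CCCCc1nc(C)c(CC(=O)N2CCC[C@H]2C(=O)OC)c(=O)n1Cc1ccc(-c2ccccc2-c2nnn[nH]2)cc1`: 0.043 mg/kg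

Compound 3 has the second highest of these three numbers, with compound 2 lower and compound 1 higher. Compound 4 `CCCCc1nc(C)c(CC(=O)N2CCSCC2)c(=O)n1Cc1ccc(-c2ccccc2-c2nnn[nH]2)cc1` carries thiomorpholin-4-yl in place of 2-(methoxycarbonyl)pyrrolidin-1-yl on a carbonyl carbon. Among the compounds with values here, no measured step makes this exact exchange. The closest is the modest exchange of one amide group for another, a 2.4-fold higher number from compound 2 to compound 3 (0.38 log units; beyond the scatter). Replacing hydroxy gave larger modest steps, a 7.2-fold lower number from compound 1 to compound 2 (0.86 log units; beyond the scatter) and a 3.0-fold lower number from compound 1 to compound 3 (0.48 log units; beyond the scatter), but compound 4 already lacks that hydroxy. In this assay only a small expected change is therefore estimated, a 1.4-fold lower number from compound 3 to compound 4 (0.16 log units; within the scatter), not clearly beyond the scatter. For compound 4 the estimate is 0.03 mg/kg, with an expected range of 0.01 mg/kg to 0.09 mg/kg.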

Compound 4, dose for half-maximal effect: 0.038 mg/kg
For compound 4 the middle estimate is 1.3-fold (0.10 log units) below the measured one; low and high end bracket the measured number.
By their numbers in this assay, from the lowest: compound 2; then compounds 4 and 3 (each within the scatter of the next); then compound 1.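

In this assay, exchanging 2-(methoxycarbonyl)pyrrolidin-1-yl, with its methoxycarbonyl group and defined stereocentre, for the six-membered thiomorpholin-4-yl on this carbonyl carbon leaves the read-out within the scatter (a 1.1-fold lower number from compound 3 to compound 4 (0.05 log units; within the scatter)). Thiomorpholin-4-yl also gives a lower number than hydroxy (a 3.4-fold lower number from compound 1 to compound 4 (0.53 log units; beyond the scatter)) but a higher number than dimethylamino (a 2.1-fold higher number from compound 2 to compound 4 (0.32 log units; beyond the scatter)), so both ring amides, in compound 3 and compound 4, lie beyond the scatter from dimethylamino on the higher side. No available evidence bears on this result. On these data alone, whether morpholin-4-yl or piperidin-1-yl would behave like thiomorpholin-4-yl stays open, as does whether methylamino would match dimethylamino.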